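The source may report more compounds than this note shows. Statements on the series, on what has been measured and on what is new or still open speak of the compounds shown alone.

Compound 1 `CCCCc1cc2cn(COCCO)c(=O)nc2o1`: > 200000 nM
Compound 2 `CCCCCC#Cc1cc2cn(COCCO)c(=O)nc2o1`: > 50000 nM
Compound 3 `CCCCCCCCc1cc2cn(COCCO)c(=O)nc2o1`: > 200000 nM

These were measured in a functional assay on HEL cells (Homo sapiens); a lower number here means that less compound is tolerated, a higher number that more compound is tolerated. For compound 1 the reading is a limit of the assay, not a number. For compound 2 the reading is likewise a limit. For compound 3 the reading is likewise a limit.

The change from compound 1 to compound 3 is butyl in place of hydrogen on a saturated chain carbon, four bonds along the chain from an aromatic carbon, and the step it made is a step that the two limits leave unreadable from compound 1 to compound 3. Compound 4 `CCCCCCCCCC#Cc1cc2cn(COCCO)c(=O)nc2o1` arises from compound 2 by butyl in place of hydrogen on a saturated chain carbon, five bonds along the chain from a triple-bonded carbon. This is the same kind of change, not the same: in the first it sits four bonds along the chain from an aromatic carbon, in the second five bonds along the chain from a triple-bonded carbon. The two cores differ by hept-1-yn-1-yl in place of butyl on an aromatic carbon, a step that the two limits leave unreadable from compound 1 to compound 2. What is known is the limit of > 200000 nM in this assay, at which 2 of the 3 values shown sit, and (the limit of > 50000 nM in this assay, at which 1 of the 3 values shown sits).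

Compound 4 is therefore expected to sit at 200000 nM in this assay, most likely again as a limit. The expected step is a step that the limit leaves unreadable from compound 2 to compound 4, resting on (the limit of > 200000 nM in this assay, at which 2 of the 3 values shown sit), where compound 3 already carries the lengthened chain.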

Compound 4, half-maximal cytotoxic concentration: > 50000 nM
Compound 4 ended at the assay's limit (the forecaster's own chance of this, stated with the estimate: 85%); the middle value does not contradict the limit.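

Compound 2 reads > 50000 nM, a limit of the assay and not a number. Compound 4 reads > 50000 nM, likewise a limit. For the compounds shown here, no step from butyl in place of hydrogen can therefore be read between these two compounds. The compounds shown leave open where any of them would give a real number in this assay, and whether the longer chain changes it.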